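A Sulfonyl Group Exchange at the Cytotoxicity Limit

This account rests on a few compounds, and the source may have more. Where it says the series, first, only, none or still open, it means among the compounds named here.

In a functional assay on HEK293 cells (Homo sapiens) for cytotoxicity (a lower number here means that less compound is tolerated, a higher number that more compound is tolerated), compound 1 (`COc1ccc([C@H]2CC(=O)N(c3ccccc3)C2)cc1OC1CCCC1`) gives > 10000 nM as a limit of the assay, not a number. Compound 2 (`COc1ccc([C@H]2CC(=O)N(c3cccc(NS(=O)(=O)c4cccc(Cl)c4)c3)C2)cc1OC1CCCC1`), which carries ((3-chlorophenyl)sulfonyl)amino in place of hydrogen on an aromatic carbon, gives > 10000 nM as a limit too. Within the data shown here, the only measured step (a step that the two limits leave unreadable from compound 1 to compound 2) therefore has no size to carry forward, and the evidence so far comes down to one observation (the limit of > 10000 nM in this assay, at which 2 of the 2 values shown sit).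

Compound 3 (`COc1ccc([C@H]2CC(=O)N(c3cccc(NS(=O)(=O)c4c(F)cccc4F)c3)C2)cc1OC1CCCC1`) differs from compound 2 only in the group on the sulfonyl sulfur, where 2,6-difluorophenyl stands in place of 3-chlorophenyl (2,6-difluorophenyl in place of 3-chlorophenyl on a sulfonyl sulfur). Among the measured compounds shown here, no measured step tests this exchange directly. Compound 2 stands at a limit (> 10000 nM) with its 3-chlorophenyl group, so the expectation rests on that limit alone. No step beyond the scatter is expected in this assay, and no direction can be argued. In numbers, the expected step is this one (a step that the limit leaves unreadable from compound 2 to compound 3). For compound 3 the estimated value is 15000 nM, with an expected range from 6000 nM to 40000 nM and a good chance that the assay again reports only a limit.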

Compound 3, half-maximal cytotoxic concentration: > 10000 nM
Compound 3: no number, only a limit; the forecaster's own chance of this, stated with the estimate: 85%; the middle value does not contradict the limit.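

In this assay compound 3 gives > 10000 nM, which is a limit and not a number. Among these compounds, no step linking compound 3 to compound 1 or compound 2 can therefore be read. The compounds shown leave open at what concentration, if any, each of the three becomes cytotoxic, and whether the sulfonyl groups make any difference there.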